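Nitro substitution on two related quinolone cores

This account rests on a few compounds, and the source may have more. Where it says the series, first, only, none or still open, it means among the compounds named here.

A series of three measured compounds and one yet to be measured was examined in a functional assay on Bel-7402 cells (Homo sapiens) for cytotoxicity, read by MTT assay, with a stated time of 48 h; a lower number here means a stronger inhibitor, a higher number a weaker inhibitor. Compound 1 `CCn1cc(-c2nc3ccccc3o2)c(=O)c2cc(F)c(N3CCN(C)CC3)cc21` gives 2000 nM in this assay. Compound 3 `CCn1cc(-c2nc3ccc([N+](=O)[O-])cc3o2)c(=O)c2cc(F)c(N3CCN(C)CC3)cc21` carries one change relative to compound 1, namely (nitro in place of hydrogen on an aromatic carbon), and this step, a 25-fold higher number from compound 1 to compound 3 (1.40 log units; beyond the scatter), leaves compound 3 at 50200 nM. Compound 2 `CCn1cc(-c2nc3ccccc3s2)c(=O)c2cc(F)c(N3CCNC(C)C3)c(F)c21` rests on a different core; the difference between the two cores is not broken down here. Compound 2 gives 15000 nM in this assay, the second highest number of the three measured, with compound 3 higher and compound 1 lower.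

Compound 4 `CCn1cc(-c2nc3ccc([N+](=O)[O-])cc3s2)c(=O)c2cc(F)c(N3CCNC(C)C3)c(F)c21` has not yet been measured. It differs from compound 2 by nitro in place of hydrogen on an aromatic carbon, the same change that compound 3 carries relative to compound 1, at the same kind of place on a fused aromatic ring. For the measured compounds named here, since the first instance of this change produced the step of a 25-fold higher number from compound 1 to compound 3 (1.40 log units; beyond the scatter), a comparable step is expected from compound 2 to compound 4, that is a 20-fold higher number from compound 2 to compound 4 (1.30 log units; beyond the scatter), although the change is seen only once among measured compounds and on a different core, so the expectation is uncertain. Compound 4 is accordingly estimated to give 300000 nM in this assay, within a range from 80000 nM to 1000000 nM.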

Compound 4, half-maximal inhibitory concentration: 4100 nM
Compound 4: middle estimate off by 73-fold (1.86 log units), on the high side; the measured number lies below the stated range.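

In this assay, nitro in place of hydrogen on an aromatic carbon gives a 3.7-fold lower number from compound 2 to compound 4 (0.56 log units; beyond the scatter), so on this core the number falls, whereas on the core of compound 1 the same change raised it. The two results do not agree in direction or in size: the same change on two cores in this assay, a 25-fold higher number (1.40 log units; beyond the scatter) from compound 1 to compound 3 and a 3.7-fold lower number (0.56 log units; beyond the scatter) from compound 2 to compound 4, 92-fold (1.96 log units) apart, beyond the scatter of two such steps This shows that, in this series, the step measured on one core could not be carried over to the other, even though the change sits at the same kind of place on a fused aromatic ring; it does not show which feature of the cores separates the two results, as they differ in more than one place and the change is seen only once on each.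

The compounds shown leave open whether a different group at this place, such as an amine or a methoxy group, would also move the number in opposite directions on the two cores. They also leave open which single difference between the cores goes with the reversal, a question that only compounds differing from these in one place at a time, with and without the nitro group, could settle.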